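A few compounds are considered here, and "the series" means these few. Any claim that something is new, unique, unknown or untested is made for them only; others in the source may bear on it.

Compound 1 `CC(C)CCn1nc(-c2cccs2)c(O)c(C2=NS(=O)(=O)c3ccccc3N2)c1=O` was tested in an in vitro ADME assay on microsomes from liver (Homo sapiens) for metabolic stability, tested at 5 uM (on this read-out lower numbers stand for a shorter-lived compound and higher numbers for a longer-lived compound), where compound 1 gives 0.2 h. Among the compounds with values here, only one other compound has been measured: compound 2 `CCC(Oc1ccc2c(c1)S(=O)(=O)N=C(c1c(O)c(-c3cccs3)nn(CCC(C)C)c1=O)N2)C(N)=O` gives 0.35 h, and a 1.8-fold higher number from compound 1 to compound 2 (0.24 log units; within the scatter), so the two numbers cannot be told apart. Compound 3 `CC(C)CCn1nc(-c2cccs2)c(O)c(C2=NS(=O)(=O)c3cc(NC(=O)C4CC4)ccc3N2)c1=O` has not yet been measured. It differs from compound 1 by (cyclopropylcarbonyl)amino in place of hydrogen on an aromatic carbon. Within the data shown here, the one measured step that bears on this change, a 1.8-fold higher number from compound 1 to compound 2 (0.24 log units; within the scatter), also placed a new group on an aromatic carbon of the shared core. On that basis no step beyond the scatter is expected, a 1.5-fold higher number from compound 1 to compound 3 (0.18 log units; within the scatter). Compound 3 is therefore estimated at 0.3 h, in a range from 0.15 h to 0.6 h.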

Compound 3, half-life: 0.0833 h
Compound 3: the middle estimate sits 3.6-fold (0.56 log units) above what was measured; the whole stated range lies above it.
By their numbers in this assay, from the lowest: compound 3; then compounds 1 and 2 (each within the scatter of the next).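

In this assay placing (cyclopropylcarbonyl)amino on this aromatic carbon gives a 2.4-fold lower number from compound 1 to compound 3 (0.38 log units; beyond the scatter) and so shifts the half-life beyond the scatter, which 1-carbamoylpropoxy on that carbon did not do. Exchanging 1-carbamoylpropoxy for (cyclopropylcarbonyl)amino gives a 4.2-fold lower number from compound 2 to compound 3 (0.62 log units; beyond the scatter) and shows that the group placed here can change this read-out. Nothing measured here explains the drop.
Still open, on these data alone, is whether the amide link or the cyclopropyl ring goes with the shorter half-life. An acetylamino group or a plain amine on this carbon would separate the two.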